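The source may hold more compounds than are shown below. What is called first, only, known or untested is meant among the compounds shown, and "the series" means these compounds.

Compound 1 `O=C(/C=C/c1ccc([N+](=O)[O-])o1)c1ccc(Br)cc1` and compound 2 `O=C(/C=C/c1ccc([N+](=O)[O-])o1)c1ccc(I)cc1` share one core, while compound 3 `COc1ccc(/C=C/C(=O)c2cccc(Br)c2)cc1` is built on another; the difference between the two cores is not broken down here. In a functional assay on C6 cells (Rattus norvegicus) for inhibition, read by sulforhodamine B assay, with a stated time of 72 h (on this read-out higher numbers stand for an effect only at larger amounts of compound and lower numbers for an effect already at smaller amounts), compound 1 gives 2700 nM and compound 2 gives 2100 nM, a step of a 1.3-fold lower number from compound 1 to compound 2 (0.11 log units; within the scatter), made by iodo in place of bromo on an aromatic carbon. In this assay compound 3 gives 22300 nM, the highest of the three numbers. Compound 4 `COc1ccc(/C=C/C(=O)c2cccc(I)c2)cc1` is made from compound 3 by iodo in place of bromo on an aromatic carbon. This is the same kind of change as before, but the place differs: para to a large group in compound 1, meta to a large group in compound 3. The step is expected to be about a 1.3-fold lower number from compound 3 to compound 4 (0.12 log units; within the scatter), resting on the small step of a 1.3-fold lower number from compound 1 to compound 2 (0.11 log units; within the scatter). Compound 4 is therefore estimated at 17000 nM, between 8000 nM and 35000 nM.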

Compound 4, half-maximal effective concentration: 14600 nM
Compound 4: middle estimate off by 1.2-fold (0.07 log units), on the high side; low and high end bracket the measured number.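

In this assay, iodo in place of bromo on an aromatic carbon gives a 1.5-fold lower number from compound 3 to compound 4 (0.18 log units; within the scatter), and this step agrees with the earlier one on the other core: the same change on two cores in this assay, a 1.3-fold lower number (0.11 log units; within the scatter) from compound 1 to compound 2 and a 1.5-fold lower number (0.18 log units; within the scatter) from compound 3 to compound 4, 1.2-fold (0.07 log units) apart, within the scatter of two such steps. In these two pairs, then, the change carries over from one core to the other, although its place differs, and on neither core can the step be told apart from the scatter. Among these compounds, this does not show that iodo and bromo are interchangeable on every core or at every place, as only two pairs are available, and it gives no explanation for the result.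

The compounds shown leave open whether an amine or a carboxylic acid at this place would give a clearly different number. They also leave open how fluoro or chloro would compare with bromo and iodo on either core.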